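This account rests on a few compounds, and the source may have more. Where it says the series, first, only, none or still open, it means among the compounds named here.

Measured so far:
Compound 1, `Cc1cc(C(=O)O)nn1Cc1cc(Br)ccc1OCc1ccc(Cl)cc1Cl`: 0.49 nM
Compound 2, `Cc1cc(C(=O)O)nn1Cc1cc(Br)ccc1OCc1cccc(C(F)(F)F)c1`: 1100 nM

In a functional assay on CHO-K1 cells for antagonist activity at prostaglandin E2 receptor EP1 subtype (Homo sapiens), read by FLIPR (a lower number here means a stronger inhibitor, a higher number a weaker inhibitor), compound 1 gives 0.49 nM, the lower of the two numbers, while compound 2 gives 1100 nM, a gap far beyond the scatter. Compound 3, `Cc1cc(C(=O)O)nn1Cc1cc(Br)ccc1OCc1cc(Cl)cc(Cl)c1`, is not yet measured. It differs from compound 1 in one place: 3,5-dichlorophenyl in place of 2,4-dichlorophenyl on a saturated chain carbon bound to an oxygen on an aromatic ring. The same atoms are kept; only their arrangement on the ring changes. Among the measured compounds shown here, no pair of measured compounds differs in just one place, so no measured step guides this one. Still, compound 2 shows that a different group in the same place comes with a much higher number, 1100 nM, so rearranging the dichlorophenyl group seems more likely to cost activity than to add to it. The expected step of a 120-fold higher number from compound 1 to compound 3 (2.09 log units; beyond the scatter) is a loss beyond the scatter. Compound 3 is estimated at 60 nM, in a range from 6 nM to 600 nM.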

Compound 3, inhibition constant: 1120 nM
Compound 3: the middle estimate sits 19-fold (1.27 log units) below what was measured; the whole stated range lies below it.
By their numbers in this assay, from the lowest: compound 1; then compounds 2 and 3 (each within the scatter of the next).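

Swapping 2,4-dichlorophenyl for 3,5-dichlorophenyl keeps the same atoms yet gives a 2300-fold higher number from compound 1 to compound 3 (3.36 log units; beyond the scatter) in this assay with nothing added or removed. This position on the saturated chain carbon bound to an oxygen on an aromatic ring therefore responds strongly to where the two chlorines lie, and not only to which atoms are present. Nothing here measures why the arrangement matters so much.

As far as these compounds go, it remains open which of the two chlorines of compound 1 carries the activity, and whether a fluorine or a methoxy group could take the place of either one. From the compounds shown here alone, it is also open whether the same sharp loss would appear if the bromine on the shared core were replaced by a nitrile.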